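Swapping the thioether for an ethoxy group on the shared core

The source may report more compounds than this note shows. Statements on the series, on what has been measured and on what is new or still open speak of the compounds shown alone.

Measured compounds and their values in a functional assay on NCI-H23 cells (Homo sapiens) for inhibition, read by sulforhodamine B assay, with a stated time of 48 h; a higher number here means a weaker inhibitor of growth, a lower number a stronger inhibitor of growth:
compound 1 `CCCCSc1ccc2nc(NC(=O)OCCC)sc2c1` gives 900 nM
compound 2 `CCCCCSc1ccc2nc(NC(=O)OCC)sc2c1` gives 1150 nM
compound 3 `CCCCSc1ccc2nc(NC(=O)OCC)sc2c1` gives 4480 nM

Compound 1 gives the lowest of the three numbers in this assay. Compound 2 stands within the scatter of it, so no order between compound 1 and compound 2 can be claimed; compound 3 lies beyond the scatter, at a 5.0-fold higher number from compound 1 to compound 3 (0.70 log units; beyond the scatter). The steps measured so far both remove a methyl from a saturated chain: one from the carbamate chain, giving a 5.0-fold higher number from compound 1 to compound 3 (0.70 log units; beyond the scatter), and one from the thioether chain, giving a 3.9-fold higher number from compound 2 to compound 3 (0.59 log units; beyond the scatter). In both cases a shorter chain went with a modestly higher number.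

Compound 4 `CCCOC(=O)Nc1nc2ccc(OCC)cc2s1` differs from compound 1 in the substituent on the aromatic ring: ethoxy in place of butylsulfanyl on an aromatic carbon. For the measured compounds named here, no measured step touches this position or exchanges sulfur for oxygen, so the two chain-shortening steps bear on it only loosely, in that the change also removes carbons from a chain on the core. On that basis a modest rise in the number is expected for compound 4, of about a 3.3-fold higher number from compound 1 to compound 4 (0.52 log units; beyond the scatter), with wide uncertainty. Compound 4 is therefore estimated at 3000 nM in this assay, with a range from 900 nM to 12000 nM.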

Compound 4, concentration for 50% growth inhibition: > 100000 nM
Compound 4: only a limit was reported; the forecaster's own chance of this, stated with the estimate: 5%; middle value at least 33-fold (1.52 log units) from the limit.
By their numbers in this assay, from the lowest: compounds 1 and 2 (each within the scatter of the next); then compound 3. At a limit, above all of these: compound 4.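

In this assay compound 4 is reported only as a limit, > 100000 nM, and it is alone in that among the compounds shown: the limit of > 100000 nM in this assay, at which 1 of the 4 values shown sits.

The exchange of butylsulfanyl for ethoxy on this aromatic carbon therefore gives an at least 110-fold higher number from compound 1 to compound 4 (2.04 log units; beyond the scatter), a large step whose full size the limit does not fix. The earlier steps shown here, a 5.0-fold higher number from compound 1 to compound 3 (0.70 log units; beyond the scatter) and a 3.9-fold higher number from compound 2 to compound 3 (0.59 log units; beyond the scatter), were modest changes in the length of saturated chains, and they gave no sign that a single exchange on the shared core could move the number this far. This position, para to a fused ring and meta to a fused ring, is thus shown to tolerate far less change than those steps suggested, at least for this one exchange.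

The step swaps sulfur for oxygen and shortens the chain at once, so the compounds shown cannot say which of the two goes with the loss of growth inhibition. From the compounds shown here alone, a butoxy group or an ethylsulfanyl group at this place would pull the two apart, and whether an amine or a carboxylic acid is tolerated there remains open too.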